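The compounds below may be only part of what the source reports. "The series", "measured", "known", "first", "only" and "open" are said of these compounds alone.

Working notes on the series in an assay on HEK293 cells for inhibition of sodium-dependent dopamine transporter (Homo sapiens), read by scintillation counting, with stated times of 5 min and 1 min; on this read-out higher numbers stand for weaker inhibition and lower numbers for stronger inhibition.

Compound 1 `Cc1cc(O)nc(C[S+]([O-])C(c2ccccc2)c2ccccc2)n1` gives 109000 nM in this assay. Compound 2 `Cc1cnc(C[S+]([O-])C(c2ccccc2)c2ccccc2)nc1` gives 156000 nM in this assay. For the measured compounds named here, the one step between measured compounds, a 1.4-fold higher number from compound 1 to compound 2 (0.16 log units; within the scatter), changes the ring on the saturated chain carbon bound to a sulfur and stays within the scatter, so the two values cannot be ordered; compound 2 has the higher of the two numbers, with compound 1 as its nearest neighbour.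

Compound 3 `[O-][S+](Cc1cc(C2CC2)on1)C(c1ccccc1)c1ccccc1` is not yet measured. Its difference from compound 2 is 5-cyclopropyl-1,2-oxazol-3-yl in place of 5-methylpyrimidin-2-yl on a saturated chain carbon bound to a sulfur. Going by the values given here, the only step that bears on it is a 1.4-fold higher number from compound 1 to compound 2 (0.16 log units; within the scatter), which also swapped the group at the same place and moved the number by less than the scatter. Among the compounds with values here, that step, however, exchanged two six-membered aromatic rings, while here a five-membered aromatic ring carrying a three-membered ring enters; there is no measured step of that kind.

On this basis no movement beyond the scatter is expected from compound 2 to compound 3 in this assay, with a 1.1-fold lower number from compound 2 to compound 3 (0.05 log units; within the scatter) as the expected step. Compound 3 is therefore estimated at 140000 nM in this assay, with a range from 45000 nM to 450000 nM.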

Compound 3, half-maximal inhibitory concentration: 38600 nM
Beside the measured number, compound 3's estimate is 3.6-fold (0.56 log units) above it, and the stated range ends above it.
By their numbers in this assay, from the lowest: compound 3; then compounds 1 and 2 (each within the scatter of the next).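

In this assay, the group on the saturated chain carbon bound to a sulfur now moves the number beyond the scatter: 5-cyclopropyl-1,2-oxazol-3-yl in place of 5-methylpyrimidin-2-yl gives a 4.0-fold lower number from compound 2 to compound 3 (0.61 log units; beyond the scatter), and in place of 4-hydroxy-6-methylpyrimidin-2-yl it gives a 2.8-fold lower number from compound 1 to compound 3 (0.45 log units; beyond the scatter), both modest. The earlier step between the two six-membered aromatic rings stayed within the scatter, so this place could have seemed indifferent to the group; with a five-membered aromatic ring carrying a three-membered ring of carbon only, compound 3 reaches 38600 nM, the lowest number of the three, although the shift is small on the scale of these values. Nothing at hand accounts for this shift.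

Because the five-membered ring and the cyclopropyl enter together, the compounds shown do not separate their shares in the step, and 5-methyl-1,2-oxazol-3-yl or plain 1,2-oxazol-3-yl would be needed to divide them. Going by these compounds, it also remains open how a phenyl ring, an amine or a carboxylic acid at this place would read, and whether any group here gives a much lower number.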